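A few compounds are considered here, and "the series" means these few. Any claim that something is new, unique, unknown or untested is made for them only; others in the source may bear on it.

Measured in a functional assay on PC-3 cells (Homo sapiens) for cytotoxicity, read by sulforhodamine B assay; on this read-out lower numbers stand for stronger inhibition of growth and higher numbers for weaker inhibition of growth:
compound 1 `COc1cccc(OC)c1OCCNCCOc1ccccc1OCc1ccccc1`: 26900 nM
compound 2 `COc1cccc(OC)c1OCCNCCOc1ccccc1OCc1cccc(Cl)c1`: 5900 nM
compound 3 `COc1cccc(OC)c1OCCNCCOc1ccccc1OCc1ccc(Cl)cc1`: 2400 nM

Compound 3 holds the lowest number of the three; the nearest is compound 2, as a 2.5-fold lower number from compound 2 to compound 3 (0.39 log units; beyond the scatter) shows, and the furthest is compound 1, per an 11-fold lower number from compound 1 to compound 3 (1.05 log units; beyond the scatter). Compound 4 `COc1cccc(OC)c1OCCNCCOc1ccccc1OCc1ccccc1C` is not yet measured. It differs from compound 3 by 2-methylphenyl in place of 4-chlorophenyl on a saturated chain carbon bound to an oxygen on an aromatic ring. Going by the values given here, the steps that bear on it are the chloro steps, a 4.6-fold lower number from compound 1 to compound 2 (0.66 log units; beyond the scatter) and an 11-fold lower number from compound 1 to compound 3 (1.05 log units; beyond the scatter), both beyond the scatter. Among the compounds with values here, no measured step covers a methyl in this place, so the gain tied to the chloro is taken as lost and nothing is credited to the methyl. A step in this assay toward a higher number is expected, a 4.2-fold higher number from compound 3 to compound 4 (0.62 log units; beyond the scatter). Compound 4 is estimated at 10000 nM, range 3000 nM to 35000 nM.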

Compound 4, concentration for 50% growth inhibition: 11500 nM
The estimate for compound 4 lay 1.2-fold (0.06 log units) below the measured number, and the stated range covers the measured number.
By their numbers in this assay, from the lowest: compound 3; then compounds 2 and 4 (each within the scatter of the next); then compound 1.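

In this assay the gain at this place is not confined to chloro, since 2-methylbenzyl also gives a lower number than the plain benzyl group (a 2.3-fold lower number from compound 1 to compound 4 (0.37 log units; beyond the scatter)). 2-Methylbenzyl and 3-chlorobenzyl cannot be told apart (a 1.9-fold higher number from compound 2 to compound 4 (0.29 log units; within the scatter)), whereas 4-chlorobenzyl keeps a clear lead over 2-methylbenzyl (a 4.8-fold higher number from compound 3 to compound 4 (0.68 log units; beyond the scatter)). Nothing available explains these differences.

Open, from the compounds shown here alone, is how a methoxy, a fluoro or an amine would read in place of the chloro or methyl. Also open, going by these compounds, is whether any other group at this place would match 4-chlorobenzyl.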